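This account rests on a few compounds, and the source may have more. Where it says the series, first, only, none or still open, it means among the compounds named here.

The measured compounds, each in an ADME assay on the whole organism for cytotoxicity, with Artemia salina as the target, with a stated time of 24 h; a lower number here means that less compound is needed, a higher number that more compound is needed for the effect:

Compound 1 `COc1ccc(/C=C/C(=O)c2ccccc2NC(=O)NS(=O)(=O)c2ccc(C)cc2)cc1OC` gives 12.9 ug/mL.
Compound 2 `Cc1ccc(S(=O)(=O)NC(=O)Nc2ccccc2C(=O)/C=C/c2ccccc2[N+](=O)[O-])cc1` gives 40.1 ug/mL.
Compound 3 `Cc1ccc(S(=O)(=O)NC(=O)Nc2ccccc2C(=O)/C=C/c2ccc(Cl)cc2)cc1` gives 6.92 ug/mL.

Compound 3 has the lowest of the three numbers. Its nearest neighbour is compound 1, with a 1.9-fold lower number from compound 1 to compound 3 (0.27 log units; within the scatter), a step that lies within the scatter; its furthest is compound 2, with a 5.8-fold lower number from compound 2 to compound 3 (0.76 log units; beyond the scatter), a step beyond the scatter. Compound 4 `Cc1ccc(S(=O)(=O)NC(=O)Nc2ccccc2C(=O)/C=C/c2cccc(Br)c2)cc1` differs from compound 3 in one place: 3-bromophenyl in place of 4-chlorophenyl on a double-bonded chain carbon bound to a double-bonded chain carbon.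

Among the measured compounds shown here, two measured steps bear on this change, both exchanging the aryl group at the same place: a 1.9-fold lower number from compound 1 to compound 3 (0.27 log units; within the scatter), within the scatter, and a 5.8-fold lower number from compound 2 to compound 3 (0.76 log units; beyond the scatter), beyond it. As far as these compounds go, neither involves a bromine or the 3-position of the phenyl ring, so the new group is untested here. As the replacement keeps one halogen on an otherwise unsubstituted phenyl ring, with the same count of heavy atoms, donors and acceptors, the expectation for compound 4 in this assay is a step of no more than the scatter, a 1.2-fold higher number from compound 3 to compound 4 (0.06 log units; within the scatter). Compound 4 is therefore estimated at 8 ug/mL, within a range of 4 ug/mL to 20 ug/mL.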

Compound 4, concentration for half-maximal effect: 4.02 ug/mL
Compound 4: middle estimate off by 2.0-fold (0.30 log units), on the high side, within the range that was stated.
By their numbers in this assay, from the lowest: compounds 4, 3 and 1 (each within the scatter of the next, the first and the last beyond it); then compound 2.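

In this assay, the exchange of 4-chlorophenyl for 3-bromophenyl at this place on the chain gives a 1.7-fold lower number from compound 3 to compound 4 (0.24 log units; within the scatter), so a change of both the halogen and its ring position leaves the read-out within the scatter. Compound 4 also stands clearly apart from both halogen-free compounds, with a 10-fold lower number from compound 2 to compound 4 (1.00 log units; beyond the scatter) and a 3.2-fold lower number from compound 1 to compound 4 (0.51 log units; beyond the scatter), whereas the step to compound 3 from the dimethoxy compound, a 1.9-fold lower number from compound 1 to compound 3 (0.27 log units; within the scatter), did not clear the scatter. No measurement shown here accounts for these differences.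

The compounds shown change the halogen and its ring position together, so they leave the separate contribution of each open; 3-chlorophenyl or 4-bromophenyl would divide the two. As far as these compounds go, it also remains open how a phenyl ring carrying an amine or a carboxylic acid would read at this place.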